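Swapping chloro for methoxy in compound 1

The source may hold more compounds than are shown below. What is called first, only, known or untested is meant among the compounds shown, and "the series" means these compounds.

Compound 1 `Nc1ccccc1NC(=O)c1ccc(CSC(=S)N2CCN(c3ccc(Cl)cc3)CC2)cc1` stands lowest of the three measured compounds: in a functional assay on HeLa cells (Homo sapiens) for antiproliferative activity, read by CCK-8 assay, with a stated time of 72 h, tested at 8 uM (on this read-out higher numbers stand for a stronger effect at the one concentration tested and lower numbers for a weaker effect), compound 1 gives 44.8%. Compound 2 `Nc1ccccc1NC(=O)c1ccc(CSC(=S)N2CCc3ccccc32)cc1` gives 67% in this assay, and compound 3 `CN(C(=S)SCc1ccc(C(=O)Nc2ccccc2N)cc1)c1cccnc1` gives 70.5%; the step of a number 3.5 percentage points higher from compound 2 to compound 3 (within the scatter) lies within the scatter. Compound 4 `COc1ccc(N2CCN(C(=S)SCc3ccc(C(=O)Nc4ccccc4N)cc3)CC2)cc1` differs from compound 1 by methoxy in place of chloro on an aromatic carbon. Among the compounds with values here, no measured step bears directly on this change: the one measured step concerns the group on the thiocarbonyl carbon and leaves the 4-chlorophenyl untouched. Compound 4 is therefore expected to show a step of a number 0.2 percentage points higher from compound 1 to compound 4 (within the scatter) that does not go beyond the scatter. The estimate for compound 4 in this assay is 45%, expected to fall between 30% and 60%.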

Compound 4, a percentage reported as inhibition, at one concentration (the size of the read-out at that concentration, not a potency): 52.3%
For compound 4 the middle estimate is 7.3 percentage points below the measured one; measured number inside the range.
By their numbers in this assay, from the lowest: compounds 1 and 4 (each within the scatter of the next); then compounds 2 and 3 (each within the scatter of the next).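

Within the data shown here, replacing chloro with methoxy on the aromatic carbon para to a large group gives in this assay a number 7.5 percentage points higher from compound 1 to compound 4 (within the scatter) and is the first reading at this position. At this one concentration, 4-chlorophenyl and 4-methoxyphenyl cannot be told apart, so this exchange leaves the read-out within its usual scatter. Nothing available offers an explanation for this reading. From the compounds shown here alone, whether an amine, a hydroxyl or a carboxylic acid at this place would separate from chloro and methoxy remains open. So does whether these two groups would part at other concentrations.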